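The source may hold more compounds than are shown below. What is called first, only, known or untested is meant among the compounds shown, and "the series" means these compounds.

Measured in an ADME assay on Ava5 cells (Homo sapiens) for cytotoxicity; a lower number here means that less compound is tolerated, a higher number that more compound is tolerated:
compound 1 `S=C(NCc1ccccc1)Nc1cccc(OCCCCCc2ccccc2)c1`, 32000 nM
compound 2 `NC(=S)Nc1cccc(OCCCCCOc2ccc(F)cc2)c1`, 5000 nM

Compound 2 stands lowest of the two numbers in this assay; compound 1 sits clearly higher, beyond the scatter. Compound 3 `NC(=S)Nc1cccc(OCCCCCOc2ccc(-n3cccc3)cc2)c1` differs from compound 2 in one place: 1H-pyrrol-1-yl in place of fluoro on an aromatic carbon. Among the measured compounds shown here, no step of this kind between measured compounds is available, so no measured pair supports the change. The expected step in this assay is a 1.7-fold lower number from compound 2 to compound 3 (0.22 log units; within the scatter), toward a somewhat lower number, and it may not exceed the scatter. Compound 3 is therefore estimated at 3000 nM, within a range of 800 nM to 12000 nM.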

Compound 3, half-maximal cytotoxic concentration: > 50000 nM
Compound 3 was reported as a limit; the forecaster's own chance of this, stated with the estimate: 10%; middle value at least 16-fold (1.22 log units) from the limit.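

In this assay, the place para to a large group responds strongly to substitution: 1H-pyrrol-1-yl in place of fluoro gives an at least 10-fold higher number from compound 2 to compound 3 (1.00 log units; beyond the scatter). Among the compounds shown here, the earlier compounds offered no one-place comparison, so this pair is the only reading for this position. Compound 3 is reported only as a limit, so the step has a floor but no measured size: the limit of > 50000 nM in this assay, at which 1 of the 3 values shown sits.

On these data alone, whether an amine or a carboxylic acid at this place would give a step of similar size stays open. A single pair also leaves open whether the change would hold with a longer chain.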